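Varying the tetrazole substituent: from 2-chlorophenyl to a methoxycarbonylphenyl

This account rests on a few compounds, and the source may have more. Where it says the series, first, only, none or still open, it means among the compounds named here.

Measured so far, in an assay on microsomes from brain for inhibition of Fatty-acid amide hydrolase 1 (Rattus norvegicus), read by fluorescence and HPLC, with a stated time of 60 min; on this read-out higher numbers stand for weaker inhibition and lower numbers for stronger inhibition:
compound 1 `CCCCCCCCc1ccc(OCC(=O)Cn2nnc(C)n2)cc1` gives 27 nM
compound 2 `CCCCCCCCc1ccc(OCC(=O)Cn2nnc(-c3ccccc3)n2)cc1` gives 24 nM
compound 3 `CCCCCCCCc1ccc(OCC(=O)Cn2nnc(-c3ccccc3Cl)n2)cc1` gives 32 nM

Compound 3 sits alongside the other two: the step of a 1.2-fold higher number from compound 1 to compound 3 (0.07 log units; within the scatter) and the step of a 1.3-fold higher number from compound 2 to compound 3 (0.12 log units; within the scatter) are both within the scatter, so the three numbers cannot be told apart. Compound 4 `CCCCCCCCc1ccc(OCC(=O)Cn2nnc(-c3ccc(C(=O)OC)cc3)n2)cc1` arises from compound 3 by the change (4-(methoxycarbonyl)phenyl in place of 2-chlorophenyl on an aromatic carbon). For the measured compounds named here, the steps that bear on it, a 1.1-fold lower number from compound 1 to compound 2 (0.05 log units; within the scatter) and a 1.3-fold higher number from compound 2 to compound 3 (0.12 log units; within the scatter), show that swapping the group at this ring carbon, whether methyl for phenyl or adding a chloro, has so far left this assay unmoved. Going by the values given here, no measured step involves a methoxycarbonyl, so the expectation rests on that quiet record alone. Compound 4 is therefore expected at about 30 nM, between 12 nM and 80 nM, a step of a 1.1-fold lower number from compound 3 to compound 4 (0.03 log units; within the scatter) that is expected to stay within the scatter.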

Compound 4, half-maximal inhibitory concentration: 29 nM
The estimate for compound 4 lay 1.0-fold (0.01 log units) above the measured number, within the range that was stated.
By their numbers in this assay, from the lowest: compounds 2, 1, 4 and 3 (each within the scatter of the next).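

For the compounds shown here, the ring carbon now also accepts 4-(methoxycarbonyl)phenyl, the first group here with hydrogen-bond acceptors, with no readable effect in this assay: a 1.1-fold lower number from compound 3 to compound 4 (0.04 log units; within the scatter). The same holds against the plain phenyl, a 1.2-fold higher number from compound 2 to compound 4 (0.08 log units; within the scatter), and against methyl, a 1.1-fold higher number from compound 1 to compound 4 (0.03 log units; within the scatter), so four different groups at this carbon cannot be told apart. Nothing measured here gives a reason for this flat record.

Still open, going by these compounds, is whether a carboxylic acid or an amine on this phenyl ring would move the number beyond the scatter.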